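This account rests on a few compounds, and the source may have more. Where it says the series, first, only, none or still open, it means among the compounds named here.

Measured in a toxicity assay on HaCaT cells (Homo sapiens) for cytotoxicity, read by MTT assay; on this read-out higher numbers stand for weaker inhibition and lower numbers for stronger inhibition:
- compound 1 `Oc1cc(C(F)(F)F)ccc1-c1nc(-c2ccccc2O)n(-c2cccc(C(F)(F)F)c2)n1`: 54300 nM
- compound 2 `COc1cccc(-n2nc(-c3ccc(C(F)(F)F)cc3O)nc2-c2ccccc2O)c1`: 81100 nM

In this assay, compound 2 gives 81100 nM and cannot be told apart from compound 1, which gives 54300 nM. The two compounds share a core and differ only in the aromatic ring carried on the aromatic nitrogen. Compound 3 `Cc1ccc(-n2nc(-c3ccc(C(F)(F)F)cc3O)nc2-c2ccccc2O)c(C)c1` keeps that core and changes the same substituent, with 2,4-dimethylphenyl in place of 3-methoxyphenyl on an aromatic nitrogen.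

Among the measured compounds shown here, only one measured step bears on this change: a 1.5-fold higher number from compound 1 to compound 2 (0.17 log units; within the scatter). It is small, and it is a single step. For the measured compounds named here, no measured compound carries the 2,4-dimethylphenyl group, so the evidence is thin. Going by the values given here, since the one earlier change to this ring, compound 1 to compound 2 at a 1.5-fold higher number from compound 1 to compound 2 (0.17 log units; within the scatter), stayed within the scatter, no shift beyond the scatter is expected here, and no direction can be favoured with confidence. The estimate amounts to a 1.3-fold lower number from compound 2 to compound 3 (0.12 log units; within the scatter), an expected step that stays within the scatter. Compound 3 is expected at 62000 nM, with an estimated range of 28000 nM to 135000 nM.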

Compound 3, half-maximal inhibitory concentration: 94800 nM
Estimate against measurement, compound 3: 1.5-fold (0.18 log units) below; the range from low to high includes it.
By their numbers in this assay, from the lowest: compounds 1, 2 and 3 (each within the scatter of the next).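

In this assay the 2,4-dimethylphenyl group on the aromatic nitrogen brings a 1.2-fold higher number from compound 2 to compound 3 (0.07 log units; within the scatter) and, set against the 3-(trifluoromethyl)phenyl group, a 1.7-fold higher number from compound 1 to compound 3 (0.24 log units; within the scatter) and both steps stay within the scatter. The earlier pair compared two rings that each bear one substituent, whereas this ring carries two methyl groups and has no oxygen and no hydrogen-bond acceptor, and its number still cannot be told apart from those of compound 1 and compound 2. Nothing measured here accounts for how close the three numbers lie.

Going by these compounds, all three groups at this place are substituted phenyl rings, so it stays open whether a ring bearing an amine or a carboxylic acid, or a longer alkyl chain in place of the ring, would move the number beyond the scatter in this assay. On these data alone, the two hydroxyl groups and the trifluoromethyl group on the shared core stay the same throughout, and what a chlorine or an amide in their place would do to the number is equally open.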